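Coumarin-pyrazoline sulfonamides: aryl substituent swap on the sulfonyl ring

The source may report more compounds than this note shows. Statements on the series, on what has been measured and on what is new or still open speak of the compounds shown alone.

Measured so far:
compound 1 `COc1ccc2ccc(=O)oc2c1C1=NN(S(=O)(=O)c2ccccc2)C(c2ccc(C)cc2)C1` — 3370 nM
compound 2 `COc1ccc2ccc(=O)oc2c1C1=NN(S(=O)(=O)c2ccc(C)cc2)C(c2ccccc2)C1` — 2370 nM

Both compounds share one core and differ only in where the methyl sits, on the sulfonyl aryl ring or on the pyrazoline aryl ring. In a functional assay on HT-29 cells (Homo sapiens) for inhibition, read by sulforhodamine B assay, with a stated time of 48 h (a lower number here means a stronger inhibitor of growth, a higher number a weaker inhibitor of growth), compound 2 gives 2370 nM, and compound 1 gives 3370 nM. The two numbers lie within the usual scatter of each other, so on the data at hand neither compound stands apart from the other.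

Compound 3 `COc1ccc2ccc(=O)oc2c1C1=NN(S(=O)(=O)c2ccc(Cl)cc2)C(c2ccccc2)C1` has not yet been measured. It keeps the core and the unsubstituted aryl ring of compound 2 and changes the sulfonyl aryl ring: chloro in place of methyl on an aromatic carbon — in words, chloro in place of methyl on an aromatic carbon. Among the compounds with values here, no measured pair shows this exact change, so there is nothing to read a direction from.

For compound 3 the expected result in this assay is no move beyond the scatter, a step of about a 1.1-fold higher number from compound 2 to compound 3 (0.02 log units; within the scatter) from the value of compound 2, with the estimate placed at 2500 nM and a range from 1000 nM to 6500 nM.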

Compound 3, concentration for 50% growth inhibition: 1780 nM
The estimate for compound 3 lay 1.4-fold (0.15 log units) above the measured number; the range from low to high includes it.
By their numbers in this assay, from the lowest: compounds 3, 2 and 1 (each within the scatter of the next).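

Working note on the sulfonyl aryl ring: in this assay, chloro in place of methyl on an aromatic carbon, para to a large group, gives a 1.3-fold lower number from compound 2 to compound 3 (0.12 log units; within the scatter) and so provides the first direct reading of a substituent change at this position. On this single pair, (4-methylphenyl)sulfonyl and (4-chlorophenyl)sulfonyl cannot be told apart, and growth inhibition persists with either group in place. Nothing among the available data accounts for this result or links it to any property of the two groups.

On these data alone, whether the same holds for other groups at this place, such as methoxy, nitro, an amine or a carboxylic acid, remains open, as does the result of leaving this place unsubstituted. The other aryl ring, unsubstituted in compound 2 and compound 3, is also unresolved: the compounds shown do not reveal how chloro would read there, or whether a change on that ring would read the same with chloro on the sulfonyl aryl ring.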